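The source may report more compounds than this note shows. Statements on the series, on what has been measured and on what is new or still open speak of the compounds shown alone.

Measured so far:
compound 1 `CCOc1ccc(-c2c(C#N)c(N)nc(SCc3ccn[nH]3)c2C#N)cc1` — 18%
compound 2 `N#Cc1c(N)nc(SCc2cccnc2)c(C#N)c1-c1ccc(OCC2CC2)cc1` — 19%

In an assay on CHO cells for displacement of a labelled ligand from adenosine receptor A3 (Homo sapiens), read by scintillation counting, with a stated time of 120 min, tested at 1 uM (a higher number here means more inhibition at the concentration tested (going by the name of the read-out), a lower number less inhibition), compound 1 gives 18%. In this assay compound 2 gives 19%, the larger of the two numbers, but the gap to compound 1 lies within the usual scatter of repeated measurements, so the two compounds cannot be told apart on these data.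

Compound 3 `COC(=O)CSc1nc(N)c(C#N)c(-c2ccc(OCC3CC3)cc2)c1C#N` has not yet been measured. It differs from compound 2 in one place: methoxycarbonyl in place of pyridin-3-yl on a saturated chain carbon bound to a sulfur. Within the data shown here, no pair of measured compounds shows the effect of a change of this kind, so no measured step can guide the expectation. With both measured values sitting close together and low, compound 3 is expected to land in a similar region, with at most a small step from compound 2 to compound 3 estimated as a number 4 percentage points lower from compound 2 to compound 3 (within the scatter), not clearly beyond the scatter in either direction. Compound 3 is therefore expected to give about 15%, within a range from 0% to 35%.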

Compound 3, a percentage reported as inhibition, at one concentration (the size of the read-out at that concentration, not a potency): 1%
Compound 3: the middle estimate sits 14 percentage points above what was measured, and the stated range covers the measured number.
By their numbers in this assay, from the lowest: compound 3; then compounds 1 and 2 (each within the scatter of the next).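

Among these compounds, this is the first readable step at the saturated chain carbon bound to a sulfur: in this assay, methoxycarbonyl in place of pyridin-3-yl gives a number 18 percentage points lower from compound 2 to compound 3 (beyond the scatter) and so moves the read-out beyond the usual scatter. The group at this place therefore affects inhibition at the concentration tested, and this ringless group of 4 heavy atoms does less well here than the aromatic ring of 6 heavy atoms. Nothing available explains the loss, and this single step cannot separate the missing ring, the change in size and the extra hydrogen-bond acceptor.

On these data alone, it remains open whether a phenyl, a carboxylic acid or an amide at this place would match compound 2 or fall nearer compound 3. As far as these compounds go, it is also open how a longer chain between the sulfur and the methoxycarbonyl would behave.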